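The source may hold more compounds than are shown below. What is called first, only, known or untested is meant among the compounds shown, and "the series" means these compounds.

Of the compounds shown here, three built on one shared macrocyclic core have been measured in an ADME assay on cells (Homo sapiens) for activation; on this read-out lower numbers stand for higher toxicity in this test and higher numbers for lower toxicity in this test. Compound 1 `COc1ccc2c(OCC[C@@H]3NC(=O)N(C)CCCC/C=C\[C@@H]4C[C@@]4(C(=O)NS(=O)(=O)C4(C)CC4)NC3=O)cc(-c3nc(C(C)C)cs3)nc2c1F` gives 57100 nM. Compound 2 `COc1ccc2c(OCC[C@@H]3NC(=O)N(C)CCCC/C=C\[C@@H]4C[C@@]4(C(=O)NS(=O)(=O)C4(C)CC4)NC3=O)cc(-n3ccc(C(C)C)n3)nc2c1C` gives 25600 nM. Compound 3 `COc1ccc2c(OCC[C@@H]3NC(=O)N(C)CCCC/C=C\[C@@H]4C[C@@]4(C(=O)NS(=O)(=O)C4(C)CC4)NC3=O)cc(-c3nc(C(C)C)cs3)nc2c1C` gives 31900 nM. Among these three numbers compound 3 stands second highest; its nearest neighbour is compound 2 and its furthest is compound 1, and both gaps lie within the scatter. The two steps that lead to compound 3 are correspondingly small: a 1.8-fold lower number from compound 1 to compound 3 (0.25 log units; within the scatter), and a 1.2-fold higher number from compound 2 to compound 3 (0.10 log units; within the scatter).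

Compound 4 `CCCn1cc(-c2cc(OCC[C@@H]3NC(=O)N(C)CCCC/C=C\[C@@H]4C[C@@]4(C(=O)NS(=O)(=O)C4(C)CC4)NC3=O)c3ccc(OC)c(C)c3n2)cn1` has not yet been measured in this assay. It differs from compound 3 in one place: 1-propyl-1H-pyrazol-4-yl in place of 4-isopropyl-1,3-thiazol-2-yl on an aromatic carbon. Among the measured compounds shown here, of the measured steps, the one from compound 2 to compound 3 bears most directly on this change, since it also swaps one five-membered aromatic ring with two hetero atoms for another and remains within the scatter; the step from compound 1 to compound 3 concerns a different group and is likewise within the scatter. On this basis compound 4 is expected to sit close to compound 3 in this assay, with an expected step of a 1.1-fold lower number from compound 3 to compound 4 (0.03 log units; within the scatter), that is, none beyond the scatter. The estimate for compound 4 in this assay is 30000 nM, with a range from 12000 nM to 75000 nM.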

Compound 4, half-maximal cytotoxic concentration: 62300 nM
Beside the measured number, compound 4's estimate is 2.1-fold (0.32 log units) below it; the range from low to high includes it.
By their numbers in this assay, from the lowest: compounds 2, 3, 1 and 4 (each within the scatter of the next, the first and the last beyond it).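

In this assay, the place next to the ring nitrogen now carries 1-propyl-1H-pyrazol-4-yl, and exchanging 4-isopropyl-1,3-thiazol-2-yl for it gives a 2.0-fold higher number from compound 3 to compound 4 (0.29 log units; within the scatter), so this exchange joins the earlier ring swap at this place in staying within the scatter. Set against 3-isopropyl-1H-pyrazol-1-yl, the same group gives a 2.4-fold higher number from compound 2 to compound 4 (0.39 log units; beyond the scatter), a modest step and the only one shown at this place that passes beyond the scatter. The group that leaves compound 3 and the group that enters compound 4 match in heavy atoms, ring type, hydrogen-bond donors and acceptors, and nothing in the available data accounts for either step.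

The compounds shown leave open whether the step from 3-isopropyl-1H-pyrazol-1-yl goes with the point of attachment of the pyrazole or with the propyl chain in place of isopropyl, two features that differ together between compound 2 and compound 4. They also leave open how a longer chain on the pyrazole, or an amine or a carboxylic acid at the end of that chain, would read out at this place.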